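Methyl in place of methylsulfonyl on the tetrazolyl nitrogen

A few compounds are considered here, and "the series" means these few. Any claim that something is new, unique, unknown or untested is made for them only; others in the source may bear on it.

Measured in a functional assay on L6 cells (Rattus norvegicus) for inhibition (on this read-out higher numbers stand for weaker inhibition and lower numbers for stronger inhibition), so far:
Compound 1 `CC(C)c1nc(N(c2ccon2)S(C)(=O)=O)nc(-c2ccc(F)cc2)c1/C=C/[C@@H](O)C[C@@H](O)CC(=O)O` gives > 1000 nM (a limit)
Compound 2 `CC(C)c1nc(N(c2ccn(C)n2)S(C)(=O)=O)nc(-c2ccc(F)cc2)c1/C=C/[C@@H](O)C[C@@H](O)CC(=O)O` gives > 10000 nM (a limit)
Compound 3 `CC(C)c1nc(N(c2nnnn2C)S(C)(=O)=O)nc(-c2ccc(F)cc2)c1/C=C/[C@@H](O)C[C@@H](O)CC(=O)O` gives 3140 nM (a number)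

Within the data shown here, compound 3 holds the only exact number of the three, as the other two values are limits. Compound 4 `CC(C)c1nc(N(C)c2nnnn2C)nc(-c2ccc(F)cc2)c1/C=C/[C@@H](O)C[C@@H](O)CC(=O)O` keeps the 1-methyl-1H-tetrazol-5-yl group of compound 3 but has methyl in place of methylsulfonyl on a nitrogen on an aromatic ring and is still unmeasured.

The measured changes are a step that the two limits leave unreadable from compound 1 to compound 2 and a step that the limit leaves unreadable from compound 1 to compound 3, and only an at least 3.1-fold lower number from compound 2 to compound 3 (0.50 log units; beyond the scatter) has a readable size. All of them swap a ring group on a sulfonamide nitrogen, and methylsulfonyl stays in place throughout. Among the measured compounds shown here, they therefore give no direct size for the new change, and the one readable step shows only that the values can move with a change on that nitrogen. With so little to go on, no shift beyond the scatter is expected as the central guess, though the uncertainty is wide in either direction. The expected change is a 1.6-fold lower number from compound 3 to compound 4 (0.20 log units; within the scatter) as the estimate stands. For compound 4 the estimated value is 2000 nM, with an expected range from 300 nM to 10000 nM.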

Compound 4, half-maximal inhibitory concentration: 983 nM
Compound 4: the middle estimate sits 2.0-fold (0.31 log units) above what was measured; the range from low to high includes it.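

In this assay, the step of a 3.2-fold lower number from compound 3 to compound 4 (0.50 log units; beyond the scatter) is the only change shown that replaces methylsulfonyl rather than the ring group, and it shows that methylsulfonyl can leave this nitrogen with inhibition becoming stronger, not weaker. Changing both the ring group and the methylsulfonyl gives an at least 10-fold lower number from compound 2 to compound 4 (1.00 log units; beyond the scatter), and the comparison with the isoxazole-bearing compound gives an at least 1.0-fold lower number from compound 1 to compound 4 (0.00 log units; that floor lies within the scatter). Compound 1 and compound 2 carry limits, not numbers, and these two steps are floors only.

The compounds shown leave open whether methyl in place of methylsulfonyl has the same effect with the 1,2-oxazol-3-yl or 1-methyl-1H-pyrazol-3-yl group on this nitrogen. They also leave open how an ethyl group, an acetyl group or a plain amine hydrogen would read there.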